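The compounds below may be only part of what the source reports. "The series", "measured", "known", "first", "only" and "open" are said of these compounds alone.

Three compounds share one core, each with a different ring attached through the amine nitrogen. Compound 1 `FC(F)(F)c1ccc(CSc2nc(Nc3cccc(C(F)(F)F)c3)c3ccccc3n2)cc1` gives 12900 nM in a functional assay on PC-3 cells (Homo sapiens) for cytotoxicity, read by MTT assay, with a stated time of 72 h; on this read-out lower numbers stand for stronger inhibition and higher numbers for weaker inhibition. Compound 2 `O=[N+]([O-])c1cccc(Nc2nc(SCc3ccc(C(F)(F)F)cc3)nc3ccccc23)c1` gives 13500 nM. Compound 3 `Fc1ccc(Nc2nc(SCc3ccc(C(F)(F)F)cc3)nc3ccccc23)cc1` gives 7070 nM. On these numbers compound 3 sits at the lower end, but the step of a 1.8-fold lower number from compound 1 to compound 3 (0.26 log units; within the scatter) and the step of a 1.9-fold lower number from compound 2 to compound 3 (0.28 log units; within the scatter) are both within the scatter, so the three are not separated, and swapping one ring for another has not moved the read-out so far.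

Compound 4 `CCOc1ccc(Nc2nc(SCc3ccc(C(F)(F)F)cc3)nc3ccccc23)cc1` differs from compound 3 by ethoxy in place of fluoro on an aromatic carbon. The change again sits on the ring attached to the amine nitrogen, the same place altered in the steps from compound 1 and compound 2 to compound 3, both of which stayed within the scatter. On that ground the step of a 1.1-fold higher number from compound 3 to compound 4 (0.05 log units; within the scatter) is expected to stay within the scatter as well. Compound 4 is therefore estimated at 8000 nM, with a range from 3500 nM to 18000 nM.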

Compound 4, half-maximal inhibitory concentration: 32100 nM
The estimate for compound 4 lay 4.0-fold (0.60 log units) below the measured number; the whole stated range lies below it.
By their numbers in this assay, from the lowest: compounds 3, 1 and 2 (each within the scatter of the next); then compound 4.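

Ethoxy in place of fluoro on this aromatic carbon, para to a large group, produces in this assay the step of a 4.5-fold higher number from compound 3 to compound 4 (0.66 log units; beyond the scatter) and thus the first clear shift seen at this ring. The steps of a 2.4-fold higher number from compound 2 to compound 4 (0.38 log units; beyond the scatter) and a 2.5-fold higher number from compound 1 to compound 4 (0.40 log units; beyond the scatter) also lie beyond the scatter, so compound 4 is the weakest of the four, while the other three remain unseparated. The ring on the amine nitrogen can therefore change the read-out, although the earlier swaps among 3-(trifluoromethyl)phenyl, 3-nitrophenyl and 4-fluorophenyl did not show this and all three new steps are modest.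

Nothing in the data shown bears on the reason for this shift. Going by these compounds, whether methoxy, a longer alkoxy chain or an amine on this same carbon would give a number close to that of compound 3 or of compound 4 remains open.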